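Fluorine Step Repeated on a Second Core

The compounds below may be only part of what the source reports. "The series", "measured", "known", "first", "only" and "open" are said of these compounds alone.

Measured so far:
compound 1, `O=c1c(OC/C(=N/O)c2ccccc2)c(-c2ccccc2)oc2ccccc12`: 7210000 nM
compound 2, `O=c1c(OC/C(=N/O)c2ccc(F)cc2)c(-c2ccccc2)oc2ccccc12`: 6900000 nM
compound 3, `O=c1cc(-c2ccccc2)oc2ccc(OC/C(=N/O)c3ccccc3)cc12`: 700000 nM

All three numbers come from a functional assay on SK-HEP1 cells (Homo sapiens) for antiproliferative activity; on this read-out lower numbers stand for stronger inhibition of growth and higher numbers for weaker inhibition of growth. Compound 2 differs from compound 1 by fluoro in place of hydrogen on an aromatic carbon, and that change gave a 1.0-fold lower number from compound 1 to compound 2 (0.02 log units; within the scatter). Compound 3 is built from the same atoms as compound 1 joined differently; how the two cores differ is not broken down here. Compound 3 sits well below compound 1 and compound 2 in this assay.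

Compound 4, `O=c1cc(-c2ccccc2)oc2ccc(OC/C(=N/O)c3ccc(F)cc3)cc12`, awaits measurement. It differs from compound 3 by fluoro in place of hydrogen on an aromatic carbon, the same change at the same place as from compound 1 to compound 2. The expected step is a 1.1-fold lower number from compound 3 to compound 4 (0.03 log units; within the scatter), resting on the earlier result a 1.0-fold lower number from compound 1 to compound 2 (0.02 log units; within the scatter). In this assay compound 4 is therefore estimated at 650000 nM, probably between 300000 nM and 1500000 nM.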

Compound 4, concentration for 50% growth inhibition: 2800000 nM
Beside the measured number, compound 4's estimate is 4.3-fold (0.63 log units) below it; measured number above the stated range.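

In this assay, replacing phenyl with 4-fluorophenyl on the core of compound 3 gave a 4.0-fold higher number from compound 3 to compound 4 (0.60 log units; beyond the scatter) so the result seen on the core of compound 1 did not carry over. The same change therefore cannot be assumed to do the same thing on both cores, as the two steps differ by more than the usual scatter: the same change on two cores in this assay, a 1.0-fold lower number (0.02 log units; within the scatter) from compound 1 to compound 2 and a 4.0-fold higher number (0.60 log units; beyond the scatter) from compound 3 to compound 4, 4.2-fold (0.62 log units) apart, beyond the scatter of two such steps

Among these compounds, with only two cores and one pair on each, this shows that the outcome depends on the core here, but it does not show why, or what a third core would do. The compounds shown leave open how chloro, methoxy or an amine in place of that fluoro would behave on either core. They also leave open whether any such group would follow the same split between the two cores.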